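Lipophilicity after closing the amide into a ring

The source may hold more compounds than are shown below. What is called first, only, known or untested is meant among the compounds shown, and "the series" means these compounds.

Measured so far in a physicochemical assay for lipophilicity, using the shake flask method, in phosphate buffer, measured as octanol-water partition, with a stated time of 30 min, at pH 7.4; on this read-out lower numbers stand for lower lipophilicity and higher numbers for higher lipophilicity
compound 1 `COCCC(=O)Nc1cnc(NCc2c(F)ccc3c2CCO3)n2cnnc12` gives 1.4
compound 2 `CN(C)Cc1ccc(C(=O)Nc2cnc(NCc3c(F)ccc4c3CCO4)n3cnnc23)cc1` gives 1.8
compound 3 `CN(C)C(=O)c1cc(-c2cnc(NCc3c(F)ccc4c3CCO4)c3cn[nH]c(=O)c23)n(C)n1` gives 2.1

Compound 1 gives 1.4 as the lowest number of the three, clear of the usual scatter from both compound 2 and compound 3. The next molecule is compound 4 `C[C@H]1CC(=O)N(c2cnc(NCc3c(F)ccc4c3CCO4)n3cnnc23)C1` and it has not been measured yet. Relative to compound 1 the change is 4-methyl-2-oxopyrrolidin-1-yl in place of ((2-methoxyethyl)carbonyl)amino on an aromatic carbon on an aromatic carbon of a six-membered aromatic ring with 2 nitrogen. A group with no ring gives way to one five-membered non-aromatic ring with 1 hetero atom.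

Within the data shown here, no measured step makes this exact swap. The closest evidence is a number 0.40 log units higher from compound 1 to compound 2 (beyond the scatter) where 4-((dimethylamino)methyl)phenyl takes the place of 2-methoxyethyl on a carbonyl carbon. That is a different change, so it guides size and direction only loosely. Among the measured compounds shown here, compound 3 has no single-place step to compound 1 and offers only its value.

With compound 1 at 1.4 under both other values and that one step pointing upward, a modest rise is expected. The estimated size is a number 0.40 log units higher from compound 1 to compound 4 (beyond the scatter) in this assay as a working figure. Compound 4 is thus estimated at 1.8 with an expected range from 1.4 to 2.2 until the measurement arrives.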

Compound 4, distribution coefficient: 1.8
Compound 4: middle estimate and measured number agree at the digits printed; the range from low to high includes it.
By their numbers in this assay, from the lowest: compound 1; then compounds 2, 4 and 3 (each within the scatter of the next).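

Measured by this assay the swap of ((2-methoxyethyl)carbonyl)amino for 4-methyl-2-oxopyrrolidin-1-yl gives a number 0.40 log units higher from compound 1 to compound 4 (beyond the scatter) and is the first change shown that removes the amide hydrogen at this aromatic carbon, going from 1 hydrogen-bond donor to 0. Both groups hold 7 heavy atoms, so this shift beyond the scatter comes with no change in that count, only with a different arrangement and make-up: a five-membered non-aromatic ring replaces an open chain, a carbon replaces one oxygen, and a defined stereocentre appears. No measurement here ties the shift to any one of these differences.

The compounds shown therefore leave open which part of the swap goes with the step: the ring, the lost amide hydrogen, the lost oxygen or the methyl. A 2-oxopyrrolidin-1-yl ring without the methyl, an open-chain amide with a methyl on its nitrogen in place of the amide hydrogen, or the mirror-image form at the stereocentre would each help to separate these.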